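From diethylamino to pyrrolidin-1-yl on a carbonyl carbon

A few compounds are considered here, and "the series" means these few. Any claim that something is new, unique, unknown or untested is made for them only; others in the source may bear on it.

Measured in a functional assay on SW480 cells (Homo sapiens) for antiproliferative activity, read by MTT assay, with a stated time of 48 h; a higher number here means a weaker inhibitor, a lower number a stronger inhibitor:
Compound 1 `CO/N=C/C1=C/C[C@](C)(CCC=C(C)C)/C=C/[C@@H](OC(=O)C=C(C)C)[C@](C)(O)/C=C/C1=O`: 2630 nM
Compound 2 `CCN(CC)C(=O)/C1=C/C[C@](C)(CCC=C(C)C)/C=C/[C@@H](OC(=O)C=C(C)C)[C@](C)(O)/C=C/C1=O`: 11700 nM

Of the two measured compounds, compound 2 gives the higher number, 11700 nM, and is the weaker inhibitor. Compound 3 `CC(C)=CCC[C@]1(C)/C=C/[C@@H](OC(=O)C=C(C)C)[C@](C)(O)/C=C/C(=O)/C(C(=O)N2CCCC2)=C\C1` differs from it at one place: pyrrolidin-1-yl in place of diethylamino on a carbonyl carbon. Within the data shown here, the only measured step, a 4.4-fold higher number from compound 1 to compound 2 (0.65 log units; beyond the scatter), is modest but involves a different exchange on a double-bonded ring carbon, so it bears on this change only loosely. No step beyond the scatter is therefore expected in this assay, and the estimated step is a 1.3-fold lower number from compound 2 to compound 3 (0.11 log units; within the scatter). Compound 3 is expected at 9000 nM, with an estimated range of 3500 nM to 20000 nM.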

Compound 3, half-maximal inhibitory concentration: 15100 nM
Estimate against measurement, compound 3: 1.7-fold (0.22 log units) below; the range from low to high includes it.
By their numbers in this assay, from the lowest: compound 1; then compounds 2 and 3 (each within the scatter of the next).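

In this assay, the exchange of diethylamino for pyrrolidin-1-yl on the carbonyl carbon gives a 1.3-fold higher number from compound 2 to compound 3 (0.11 log units; within the scatter) and so does not separate the two amides. The ring form stays apart from the methoxyimine-bearing compound 1, with a 5.7-fold higher number from compound 1 to compound 3 (0.76 log units; beyond the scatter) on the double-bonded ring carbon, much as compound 2 does. No evidence on the cause accompanies these numbers. Still open, going by these compounds, is whether a larger ring amine such as piperidine or morpholine on this carbonyl would behave the same way. On these data alone, it is also open whether any amide here could come as low as compound 1.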